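Aryl ether variation on the bicyclic amine core

A few compounds are considered here, and "the series" means these few. Any claim that something is new, unique, unknown or untested is made for them only; others in the source may bear on it.

Compound 1 `Clc1ccncc1C1=CC2CNCC(C1)C2` gives 3 nM in an in vitro assay on SH-EP1 cells for displacement of a labelled ligand from Neuronal acetylcholine receptor; alpha4/beta2 (Homo sapiens); on this read-out lower numbers stand for stronger inhibition and higher numbers for weaker inhibition. Compound 2 `COc1ccccc1Oc1cncc(C2=CC3CNCC(C2)C3)c1` gives 1 nM in this assay, and compound 3 `Clc1ccc(Oc2cncc(C3=CC4CNCC(C3)C4)c2)cc1` gives 1.9 nM in this assay. On these three numbers compound 3 stands second highest; its gap to compound 1 and its gap to compound 2 both lie within the scatter, so no order among the three can be read from them. Within the data shown here, the one step that exchanges the group on the ether oxygen, a 1.9-fold higher number from compound 2 to compound 3 (0.28 log units; within the scatter), stayed within the scatter. Compound 4 `Clc1ccccc1Oc1cncc(C2=CC3CNCC(C2)C3)c1` differs from compound 3 by 2-chlorophenyl in place of 4-chlorophenyl on an oxygen on an aromatic ring. Among the measured compounds shown here, no measured step exchanges one chlorophenyl for another; the only step that bears on the change is the exchange of the whole aryl group from compound 2 to compound 3, and that was small. In this assay the expected step is therefore a 1.3-fold lower number from compound 3 to compound 4 (0.10 log units; within the scatter), with no direction beyond the scatter. Compound 4 is estimated at 1.5 nM, in the range 0.6 nM to 4 nM.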

Compound 4, inhibition constant: 0.9 nM
Beside the measured number, compound 4's estimate is 1.7-fold (0.22 log units) above it; the range from low to high includes it.
By their numbers in this assay, from the lowest: compounds 4, 2, 3 and 1 (each within the scatter of the next, the first and the last beyond it).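

Exchanging 4-chlorophenyl for 2-chlorophenyl on the ether oxygen gives a 2.1-fold lower number from compound 3 to compound 4 (0.32 log units; beyond the scatter) in this assay, so where the chloro sits on this aryl group has a modest effect on the read-out, the first step among these compounds to pass the scatter. Chloro in place of methoxy on an aromatic carbon gives a 1.1-fold lower number from compound 2 to compound 4 (0.05 log units; within the scatter), so compound 2 and compound 4 cannot be ordered, and the two groups cannot be told apart on this read-out. Nothing available accounts for the effect of the chloro placement.

The compounds shown leave open whether 3-chlorophenyl on the same oxygen would read closer to 2-chlorophenyl or to 4-chlorophenyl. They also leave open how an amine or a carboxylic acid in place of chloro on this aryl group would read.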